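A few compounds are considered here, and "the series" means these few. Any claim that something is new, unique, unknown or untested is made for them only; others in the source may bear on it.

Within the data shown here, compound 1, `CC1=C(N2CC2)C(=O)C(C(C)C)=C(N2CC2)C1=O`, is the stronger of the two quinone-type compounds measured so far. In a functional assay on L1210 cells (Mus musculus), with a stated time of 1 days (a higher number here means a more potent compound, by a factor of ten per unit of this negative logarithm, a lower number a less potent compound), compound 1 gives 4.69, the highest of the two numbers at hand. Among the measured compounds shown here, its only companion is compound 2, `CCCC1=C(N2CC2)C(=O)C(CCC)=C(N2CC2)C1=O`, which carries a propyl group on each of the two double-bonded ring carbons; in this assay compound 2 gives 4.14, a number lower than that of compound 1 by more than the usual scatter. The two compounds differ in two places at once, so their gap cannot be tied to a single change.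

Compound 3, `CCC(OC)C1=C(N2CC2)C(=O)C(C)=C(N2CC2)C1=O`, has not been measured yet. It keeps the core of compound 1 and differs from it in one place: 1-methoxypropyl in place of isopropyl on a double-bonded ring carbon. For the measured compounds named here, no measured pair shows what this change does. Compound 2 with its larger alkyl groups gives 4.14, whereas compound 1 gives 4.69. On that basis a modest downward step is expected for compound 3, a number 0.14 log units lower from compound 1 to compound 3 (within the scatter), though the added ether oxygen leaves the direction uncertain. In this assay compound 3 is estimated at 4.55, within a range from 4.05 to 5.05.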

Compound 3, logarithm of the reciprocal of the active concentration, log(1/C): 4.84
Compound 3: the middle estimate sits 0.29 log units below what was measured, within the range that was stated.
By their numbers in this assay, from the lowest: compound 2; then compounds 1 and 3 (each within the scatter of the next).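

In this assay, the swap of isopropyl for 1-methoxypropyl gives a number 0.15 log units higher from compound 1 to compound 3 (within the scatter), the first step read at this double-bonded ring carbon, next to the ring atom that bears an aziridin-1-yl group. The position therefore takes a chain of 5 heavy atoms in place of 3, including an ether oxygen counted as 1 hydrogen-bond acceptor, with no shift in the number beyond the usual scatter, so this change neither clearly gains nor clearly loses potency against the core of compound 1. Nothing at hand gives a measured property that would account for this outcome, and the result stands as an observation only.

The compounds shown leave open whether the same place would hold its number with an amine or a carboxylic acid on the side chain, or with a longer chain carrying the ether oxygen. They also leave open whether the oxygen matters on its own, since a plain butyl group or a 1-hydroxypropyl group at this carbon would be needed to separate its part from that of chain length.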